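The source may hold more compounds than are shown below. What is called first, only, known or untested is meant among the compounds shown, and "the series" means these compounds.

Measured compounds:
Compound 1, `CC1CCN(c2nc(C(F)(F)F)ccc2CNC(=O)C(c2ccc(NS(C)(=O)=O)c(F)c2)C2CCCC2)CC1`: 88.7 nM
Compound 2, `CS(=O)(=O)Nc1ccc(C(C(=O)NCc2ccc(C(F)(F)F)nc2SC2CCCCC2)C2CCCC2)cc1F`: 103 nM
Compound 3, `CC1CCN(c2nc(C(F)(F)F)ccc2CNC(=O)C(C)(C)c2ccc(NS(C)(=O)=O)c(F)c2)CC1`: 49 nM

All three were tested in an assay on CHO cells for antagonist activity at transient receptor potential cation channel subfamily V member 1 (Homo sapiens), read by FLIPR; on this read-out higher numbers stand for weaker inhibition and lower numbers for stronger inhibition. Compound 1 and compound 2 share a core and differ in one place: cyclohexylsulfanyl in place of 4-methylpiperidin-1-yl on an aromatic carbon. That change gave a 1.2-fold higher number from compound 1 to compound 2 (0.06 log units; within the scatter). Compound 3 has a different core; how the two cores differ is not broken down here. Compound 4, `CC(C)(C(=O)NCc1ccc(C(F)(F)F)nc1SC1CCCCC1)c1ccc(NS(C)(=O)=O)c(F)c1`, has not yet been measured in this assay. It stands to compound 3 as compound 2 stands to compound 1, by the same change: cyclohexylsulfanyl in place of 4-methylpiperidin-1-yl on an aromatic carbon. The expected step is a 1.2-fold higher number from compound 3 to compound 4 (0.07 log units; within the scatter), resting on the earlier pair, because the same change gave a 1.2-fold higher number from compound 1 to compound 2 (0.06 log units; within the scatter). Compound 4 is therefore estimated at 57 nM, with a likely range from 25 nM to 130 nM.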

Compound 4, inhibition constant: 65.7 nM
Compound 4: middle estimate off by 1.2-fold (0.06 log units), on the low side, and the stated range covers the measured number.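

In this assay, putting cyclohexylsulfanyl in place of 4-methylpiperidin-1-yl on the core of compound 3 gave a 1.3-fold higher number from compound 3 to compound 4 (0.13 log units; within the scatter). The change therefore carried from one core to the other without a detectable difference in its size: the same change on two cores in this assay, a 1.2-fold higher number (0.06 log units; within the scatter) from compound 1 to compound 2 and a 1.3-fold higher number (0.13 log units; within the scatter) from compound 3 to compound 4, 1.2-fold (0.06 log units) apart, within the scatter of two such steps. Going by these compounds alone, this shows only that the swap stayed within the scatter on these two cores; two pairs do not show that it would do so on a third core, and they give no reason for the agreement.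

The compounds shown leave open how a cyclohexyloxy group, a morpholin-4-yl group or an open-chain amine such as diethylamino would compare at this place. They also leave open whether the swap would behave alike on a core carrying a carboxylic acid.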